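The source may hold more compounds than are shown below. What is called first, only, known or untested is meant among the compounds shown, and "the series" means these compounds.

Compound 1 `Cc1ccc(C(=O)CC(SCC(=O)O)C(=O)O)c(C)c1`: 3830 nM
Compound 2 `Cc1ccc(C(=O)CC(SCC(=O)O)C(=O)O)cc1`: 17300 nM
Compound 3 `CC(C)(C)c1ccc(C(=O)CC(SCC(=O)O)C(=O)O)cc1`: 1390 nM

Among the measured compounds shown here, these are the three compounds measured so far in a functional assay on HeLa cells (Homo sapiens); a lower number here means a stronger inhibitor, a higher number a weaker inhibitor. Compound 2 stands highest of the three numbers, which here means the weakest inhibitor. The step of a 4.5-fold higher number from compound 1 to compound 2 (0.65 log units; beyond the scatter) was modest, and the step of a 12-fold lower number from compound 2 to compound 3 (1.10 log units; beyond the scatter) was large. Compound 4 `O=C(O)CSC(CC(=O)c1ccc(Br)cc1)C(=O)O` differs from compound 2 by bromo in place of methyl on an aromatic carbon. Both measured steps concern this same aromatic position, and both show that a number lower than that of compound 2 follows when the methyl is replaced or a substituent is present there. For the measured compounds named here, no measured step involves bromo, so the size is uncertain, but a modest lowering is expected, smaller than the tert-butyl step. Compound 4 is therefore estimated at about 8000 nM, in the range 2500 nM to 25000 nM. That estimate amounts to a step of a 2.2-fold lower number from compound 2 to compound 4 (0.33 log units; beyond the scatter).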

Compound 4, half-maximal inhibitory concentration: 9510 nM
Estimate against measurement, compound 4: 1.2-fold (0.08 log units) below; measured number inside the range.
By their numbers in this assay, from the lowest: compound 3; then compound 1; then compounds 4 and 2 (each within the scatter of the next).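

In this assay, bromo in place of methyl gives a 1.8-fold lower number from compound 2 to compound 4 (0.26 log units; within the scatter), so at this position the two groups cannot be told apart, and a change of group here does not by itself move the number beyond the scatter. Bromo in place of tert-butyl gives a 6.8-fold higher number from compound 3 to compound 4 (0.84 log units; beyond the scatter), which leaves tert-butyl as the only one of these three groups with a clear advantage at this position. No measured evidence is available to explain this difference. Going by these compounds, what an amine, a carboxylic acid or a longer chain would do at this same position remains open.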